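This account rests on a few compounds, and the source may have more. Where it says the series, first, only, none or still open, it means among the compounds named here.

For the measured compounds named here, compound 1 `Cn1c(SCC(=O)N2CCC[C@H]2C(=O)Nc2ccccc2-n2cccc2)nc2ccccc21` is one of two compounds measured in an assay on CHO cells for displacement of a labelled ligand from Orexin/Hypocretin receptor type 1 (Homo sapiens) (a higher number here means a weaker inhibitor, a lower number a stronger inhibitor), and in that assay compound 1 gives 9 nM, the higher of the two numbers. Going by the values given here, its only neighbour is compound 2 `Cc1ccc2[nH]c(SCC(=O)N3CCC[C@H]3C(=O)Nc3ccccc3-n3cccc3)nc2c1`, which in this assay gives 3 nM; the single measured step, a 3.0-fold lower number from compound 1 to compound 2 (0.48 log units; beyond the scatter), comes from exchanging the group on the sulfur. Compound 3 `Cn1c(SCC(=O)N2CCC[C@H]2C(=O)Nc2ccccc2-c2ccccc2)nc2ccccc21` differs from compound 1 in a different part of the shared core: phenyl in place of 1H-pyrrol-1-yl on an aromatic carbon. Among the compounds with values here, no measured step touches this part of the structure, so the change from compound 1 to compound 2 offers no direct guide, and compounds 1 and 2 both keep the group that now leaves. With nothing measured to go on, the expected step is small and its direction uncertain. For compound 3 a modest move towards a higher number is estimated, a 2.2-fold higher number from compound 1 to compound 3 (0.35 log units; beyond the scatter). Compound 3 is therefore expected to give about 20 nM in this assay, within a range from 5 nM to 80 nM.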

Compound 3, inhibition constant: 3 nM
Beside the measured number, compound 3's estimate is 6.7-fold (0.82 log units) above it; the whole stated range lies above it.
By their numbers in this assay, from the lowest: compounds 2 and 3 (each within the scatter of the next); then compound 1.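

For the compounds shown here, the step of a 3.0-fold lower number from compound 1 to compound 3 (0.48 log units; beyond the scatter) is the first measurement in this assay at this aromatic carbon, ortho to a large group, and it shows that the position responds to a change of ring. The 1H-pyrrol-1-yl group, a five-membered aromatic ring with a nitrogen, can give way to phenyl, a six-membered aromatic ring of carbon only, without any loss in this assay; the number falls by a margin beyond the scatter, so the ring nitrogen is not needed here for a value in this range. No measurement available here accounts for the size or direction of this step.

On these data alone, it remains open how this position would respond to a phenyl ring bearing an amine or a carboxylic acid, or to a smaller group such as methyl or a longer chain in place of the ring. Also open, as far as these compounds go, is whether phenyl would give a similar step with the 5-methyl-1H-benzimidazol-2-yl group of compound 2 on the sulfur, or whether the two changes would not add up.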